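A few compounds are considered here, and "the series" means these few. Any claim that something is new, unique, unknown or untested is made for them only; others in the source may bear on it.

Compound 1 `COc1cc(C)cc(-c2c(-c3ccnc(-c4ccc(N(C)C)cc4)c3)cnn2CC#N)c1` shows the strongest effect of the three compounds measured here. In a functional assay on OVCAR-8 cells (Homo sapiens) for cytotoxicity, read by sulforhodamine B assay, with a stated time of 48 h, tested at 0.01 uM (a higher number here means a weaker effect of the compound at the concentration tested, a lower number a stronger effect), compound 1 gives 28%. Compound 2 `COc1cc(C)cc(-c2nn(CC#N)cc2-c2ccc(-c3cccc(C(C)=O)c3)nc2)c1` gives 88% in this assay, and compound 3 `Cc1cc(O)cc(-c2nn(CC#N)cc2-c2ccnc(-c3ccc(N(C)C)cc3)c2)c1` gives 97%, both well beyond the scatter from compound 1. No direct single-change comparison exists among these three, so the weight of any one group cannot be read off. The new candidate, compound 4 `COc1cc(C)cc(-c2c(-c3ccnc(-c4ccc(C(C)=O)cc4)c3)cnn2CC#N)c1`, differs from compound 1 in one place (acetyl in place of dimethylamino on an aromatic carbon). With compound 2, which also carries an acetyl group, giving 88%, the effect of compound 4 is expected to weaken, a step of a number 42 percentage points higher from compound 1 to compound 4 (beyond the scatter) estimated to lie beyond the scatter. The value of compound 4 is estimated at 70%, within 40% to 95%.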

Compound 4, a percentage reported as activity, at one concentration (the size of the read-out at that concentration, not a potency): 83%
The estimate for compound 4 lay 13 percentage points below the measured number, within the range that was stated.
By their numbers in this assay, from the lowest: compound 1; then compounds 4, 2 and 3 (each within the scatter of the next, the first and the last beyond it).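

Exchanging dimethylamino for acetyl on this aromatic carbon, para to a large group, gives in this assay a number 55 percentage points higher from compound 1 to compound 4 (beyond the scatter), the first single-change reading among these compounds. The two groups have the same count of heavy atoms and of hydrogen-bond acceptors, yet the step is large, so this position is sensitive to the change. Nothing given here accounts for the step. As far as these compounds go, it remains open whether losing dimethylamino or gaining acetyl drives it. From the compounds shown here alone, how a primary amine or a morpholine at this place would read is also open.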